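Ester to imidazolylpropyl amide on the benzofuran ester series

The source may report more compounds than this note shows. Statements on the series, on what has been measured and on what is new or still open speak of the compounds shown alone.

Of the compounds shown here, two have been measured so far. Compound 1 `CCOC(=O)c1oc2ccc(N(Cc3ccccc3)S(=O)(=O)c3ccc(Cl)cc3)cc2c1C` gives 23200 nM in a functional assay on HCT-116 cells (Homo sapiens) for inhibition, read by MTT assay, with a stated time of 72 h; on this read-out lower numbers stand for stronger inhibition and higher numbers for weaker inhibition; compound 2 `CCOC(=O)c1oc2ccc(N(Cc3ccccc3)S(=O)(=O)c3ccc(F)cc3)cc2c1C` gives 33100 nM in the same this assay. For the measured compounds named here, the only step measured between them, a 1.4-fold higher number from compound 1 to compound 2 (0.15 log units; within the scatter), swaps one halogen for another on the aromatic ring and does not separate the two numbers. Compound 1 therefore stands on the lower of two numbers, with compound 2 within the scatter beside it.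

Compound 3 `Cc1c(C(=O)NCCCn2ccnc2)oc2ccc(N(Cc3ccccc3)S(=O)(=O)c3ccc(Cl)cc3)cc12` takes a different direction: (3-(1H-imidazol-1-yl)propyl)amino in place of ethoxy on a carbonyl carbon, the carbonyl carbon otherwise bound to an aromatic carbon of the shared core. Going by the values given here, no measured step in this assay touches the ester end of the molecule, so the halogen step between compound 1 and compound 2 bears on this change only in showing that the series sits at weak inhibition overall. Without a comparable step, the expected change a 1.5-fold lower number from compound 1 to compound 3 (0.19 log units; within the scatter) in this assay is set near zero with a broad range. Compound 3 is estimated at 15000 nM in this assay, between 3000 nM and 70000 nM.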

Compound 3, half-maximal inhibitory concentration: 5000 nM
Beside the measured number, compound 3's estimate is 3.0-fold (0.48 log units) above it; measured number inside the range.
By their numbers in this assay, from the lowest: compound 3; then compounds 1 and 2 (each within the scatter of the next).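

The ester end of the molecule is the only place in this series where a change has so far moved the number beyond the scatter: in this assay the replacement of ethoxy by (3-(1H-imidazol-1-yl)propyl)amino on the carbonyl carbon gives a 4.6-fold lower number from compound 1 to compound 3 (0.67 log units; beyond the scatter) and remains modest in size. The halogen swap, at a 1.4-fold higher number from compound 1 to compound 2 (0.15 log units; within the scatter) by contrast, did not separate its two compounds, so this carbonyl carbon is the one position shown here at which a change in the group alters the read-out. The step replaces the whole ethoxy group with an amide link, a propyl chain and an imidazole ring together, and no measurement at hand explains the shift or assigns it to any one of these parts.

As far as these compounds go, it remains open whether the imidazole ring or the amide link carries the step; a plain ethylamide, a free carboxylic acid on the same carbonyl carbon, or a shorter or longer chain ending in imidazole would separate these parts. The fluoro counterpart of compound 3 would also show whether the halogen swap stays within the scatter once the amide is in place.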